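A few compounds are considered here, and "the series" means these few. Any claim that something is new, unique, unknown or untested is made for them only; others in the source may bear on it.

Compound 1 `COc1cc2c(Nc3nc4ccc(C(=O)Nc5c(C)cccc5Cl)cc4s3)ncnc2cc1OCCCN1CCCCC1C` gives 7000 nM in a functional assay on U-937 cells (Homo sapiens) for cytotoxicity, read by WST assay, with a stated time of 72 h; a higher number here means a weaker inhibitor, a lower number a stronger inhibitor. Compound 2 `CCN(CC)CCCOc1cc2ncnc(Nc3nc4ccc(C(=O)Nc5c(C)cccc5Cl)cc4s3)c2cc1OC` gives 7300 nM in this assay.

Compound 2 holds the highest of the two numbers, with compound 1 nearest at a 1.0-fold higher number from compound 1 to compound 2 (0.02 log units; within the scatter), a step within the scatter. Compound 3 `COc1cc2c(Nc3nc4ccc(C(=O)Nc5c(C)cccc5Cl)cc4s3)ncnc2cc1OCCCN1CCCC1` differs from compound 2 by pyrrolidin-1-yl in place of diethylamino on a saturated chain carbon, three bonds along the chain from an oxygen on an aromatic ring. Within the data shown here, the only measured step at this position is the one from compound 1 to compound 2, where a six-membered ring amine gave way to diethylamino with no change beyond the scatter. A second swap of one small amine for another at the same chain position is therefore expected to move the number in this assay little, if at all, in either direction. The estimated step is a 1.0-fold lower number from compound 2 to compound 3 (0.02 log units; within the scatter). Compound 3 is estimated at 7000 nM in this assay, with a range of 3000 nM to 16000 nM.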

Compound 3, half-maximal inhibitory concentration: 19900 nM
Compound 3: the middle estimate sits 2.8-fold (0.45 log units) below what was measured, outside the stated range (above it).
By their numbers in this assay, from the lowest: compounds 1 and 2 (each within the scatter of the next); then compound 3.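

In this assay, among these compounds, the amine at the end of the propyl chain proves not to be freely exchangeable: pyrrolidin-1-yl in place of diethylamino gives a 2.7-fold higher number from compound 2 to compound 3 (0.44 log units; beyond the scatter) and is the first change at this position to go beyond the scatter. Set against 2-methylpiperidin-1-yl, the same ring gives a 2.8-fold higher number from compound 1 to compound 3 (0.45 log units; beyond the scatter), so among these three compounds pyrrolidin-1-yl stands apart from two amines that lie within the scatter of each other. Nothing available on these compounds accounts for this difference.

From the compounds shown here alone, whether a plain piperidin-1-yl or a morpholin-4-yl at this chain end would sit with compound 3 or with compound 1 and compound 2 remains open. So does whether the pyrrolidin-1-yl step would hold on a shorter chain, as in 2-(pyrrolidin-1-yl)ethyl.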